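Moving the hydroxy group on the triazole aryl

The source may hold more compounds than are shown below. What is called first, only, known or untested is meant among the compounds shown, and "the series" means these compounds.

Compound 1 `CC1(C)[C@H]2CC[C@]1(C)N(Cc1cn(-c3ccccc3C#N)nn1)C(=O)C2` carries a 2-cyanophenyl group on the five-membered aromatic ring of the shared core. Going by the values given here, in a functional assay on OVCAR-3 cells (Homo sapiens) for inhibition, read by MTT assay, with a stated time of 24 h (a higher number here means a weaker inhibitor, a lower number a stronger inhibitor), compound 1 gives 110 nM, the highest of the three numbers known so far. Compound 2 `CC1(C)[C@H]2CC[C@]1(C)N(Cc1cn(-c3ccccc3Cl)nn1)C(=O)C2` gives 40 nM, and compound 3 `CC1(C)[C@H]2CC[C@]1(C)N(Cc1cn(-c3ccccc3O)nn1)C(=O)C2` gives 90 nM. Among the steps starting from compound 1, a 2.8-fold lower number from compound 1 to compound 2 (0.44 log units; beyond the scatter) is the only one beyond the scatter, whereas a 1.2-fold lower number from compound 1 to compound 3 (0.09 log units; within the scatter) stays within it, and a 2.3-fold higher number from compound 2 to compound 3 (0.35 log units; beyond the scatter) separates the chloro and hydroxy analogues.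

Compound 4 `CC1(C)[C@H]2CC[C@]1(C)N(Cc1cn(-c3cccc(O)c3)nn1)C(=O)C2` is the compound still to be measured. It differs from compound 1 as follows: 3-hydroxyphenyl in place of 2-cyanophenyl on an aromatic nitrogen. The step from compound 1 to compound 3 bears most directly on this change because a 1.2-fold lower number from compound 1 to compound 3 (0.09 log units; within the scatter) describes the same exchange of a hydroxy group for a cyano group on the phenyl ring. Among the compounds with values here, no measured compound shows what moving the hydroxy group to a different place on that ring does, so this part of the change is untested. Compound 4 is therefore expected to give a number close to that of compound 1, estimated at 100 nM with a range from 40 nM to 250 nM. That estimate means an expected step of a 1.1-fold lower number from compound 1 to compound 4 (0.04 log units; within the scatter) that lies within the scatter.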

Compound 4, half-maximal inhibitory concentration: 370 nM
Compound 4: middle estimate off by 3.7-fold (0.57 log units), on the low side; the whole stated range lies below it.
By their numbers in this assay, from the lowest: compound 2; then compounds 3 and 1 (each within the scatter of the next); then compound 4.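

The comparison of compound 3 with compound 4 isolates the place of the hydroxy group on the phenyl ring: in this assay, 3-hydroxyphenyl in place of 2-hydroxyphenyl gives a 4.1-fold higher number from compound 3 to compound 4 (0.61 log units; beyond the scatter), so the same group does not give the same result at both places. Compound 4 also separates from the other two compounds, with a 3.4-fold higher number from compound 1 to compound 4 (0.53 log units; beyond the scatter) and a 9.3-fold higher number from compound 2 to compound 4 (0.97 log units; beyond the scatter), and its steps to all three earlier compounds are beyond the scatter, making it the weakest inhibitor of the four, whereas the exchange of cyano for hydroxy alone, seen in a 1.2-fold lower number from compound 1 to compound 3 (0.09 log units; within the scatter), stayed within the scatter. No supporting measurement is available to explain this shift.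

The compounds shown leave open whether moving a chloro or cyano group on the phenyl ring changes the number as moving the hydroxy group does. They also leave open how a phenyl ring bearing an amine, a carboxylic acid or a methoxy group would read in this assay.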